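A few compounds are considered here, and "the series" means these few. Any claim that something is new, unique, unknown or untested is made for them only; others in the source may bear on it.

Working notes on the series. Compound 1 `NC(=O)c1c(NC(=O)c2ccccc2Cl)sc2c1CCN(Cc1ccc(Cl)cc1)C2` is known in a functional assay on HeLa cells (Homo sapiens) for antiproliferative activity, with a stated time of 24 h (a higher number here means a weaker inhibitor, a lower number a stronger inhibitor), only as a limit: compound 1 gives > 50000 nM, a limit of the assay and not a number (the limit of > 50000 nM in this assay, at which 1 of the 3 values shown sits). In this assay compound 2 `NC(=O)c1c(NC(=O)c2ccccc2Cl)sc2c1CCN(Cc1cc(Cl)cc(Cl)c1)C2` gives 19600 nM and compound 3 `NC(=O)c1c(NC(=O)c2ccccc2Cl)sc2c1CCN(C(=S)Nc1ccccc1I)C2` gives 29000 nM. Compound 4 `NC(=O)c1c(NC(=O)c2ccccc2Cl)sc2c1CCN(C(=S)Nc1c(Cl)cccc1Cl)C2` has not yet been measured in this assay. It differs from compound 1 by a group of 11 heavy atoms (7 carbon, 1 nitrogen, 1 sulfur, 2 chlorine; one six-membered aromatic ring of carbon only) in place of a group of 8 heavy atoms (7 carbon, 1 chlorine; one six-membered aromatic ring of carbon only), on an amine nitrogen in a ring. Two measured steps from compound 1 bear on this change, both at the same amine nitrogen in a ring: an at least 2.5-fold lower number from compound 1 to compound 2 (0.40 log units; beyond the scatter), and an at least 1.7-fold lower number from compound 1 to compound 3 (0.23 log units; that floor lies within the scatter). Between the two measured analogues the gap is small: a 1.5-fold higher number from compound 2 to compound 3 (0.17 log units; within the scatter). Both steps away from compound 1 are floors, as compound 1 itself sits at a limit. For compound 4 a number in the region of compound 3, which gives 29000 nM, is therefore expected. The step expected is an at least 2.0-fold lower number from compound 1 to compound 4 (0.30 log units; that floor lies within the scatter). Compound 4 is estimated at 25000 nM, with a range from 9000 nM to 70000 nM.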

Compound 4, half-maximal inhibitory concentration: 26500 nM
For compound 4 the middle estimate is 1.1-fold (0.03 log units) below the measured one, within the range that was stated.
By their numbers in this assay, from the lowest: compounds 2, 4 and 3 (each within the scatter of the next). At a limit, above all of these: compound 1.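

At the amine nitrogen in a ring, this assay gives a 1.1-fold lower number from compound 3 to compound 4 (0.04 log units; within the scatter), so exchanging 2-iodophenyl for 2,6-dichlorophenyl on the amide-type nitrogen separates these two compounds by no more than the scatter. The group of compound 4 is likewise not separated from the group of compound 2, with a 1.4-fold higher number from compound 2 to compound 4 (0.13 log units; within the scatter). The remaining step, an at least 1.8-fold lower number from compound 1 to compound 4 (0.27 log units; that floor lies within the scatter), is only a floor, and the value of compound 1 is a limit of the assay and not a number, because of which this step does not fix the distance between them: the limit of > 50000 nM in this assay, at which 1 of the 4 values shown sits.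

Open, going by these compounds, is whether a carboxylic acid or an amine on the phenyl ring, or a cyclohexyl group in its place, would give a step beyond the scatter. Also open, on these data alone, is what oxygen in place of the double-bonded sulfur would give.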